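Working notes: chloro in place of methoxy, compound 3

The source may report more compounds than this note shows. Statements on the series, on what has been measured and on what is new or still open speak of the compounds shown alone.

Measured so far in a functional assay on MCF7 cells (Homo sapiens) for antiproliferative activity, read by MTT assay, with a stated time of 48 h (on this read-out higher numbers stand for weaker inhibition and lower numbers for stronger inhibition), two compounds:
- compound 1 `COc1ccc2nc(NC(c3cn(-c4ccccc4)nc3-c3ccc([N+](=O)[O-])cc3)c3c(O)ccc4ccccc34)sc2c1` gives 13300 nM
- compound 2 `COc1cccc(-c2nn(-c3ccccc3)cc2C(Nc2nc3ccc(OC)cc3s2)c2c(O)ccc3ccccc23)c1` gives 62600 nM

Compound 2 holds the higher of the two numbers, so it is the weaker inhibitor of the pair. Next is compound 3 `COc1cccc(-c2nn(-c3ccccc3)cc2C(Nc2nc3ccc(Cl)cc3s2)c2c(O)ccc3ccccc23)c1`, which differs from compound 2 by chloro in place of methoxy on an aromatic carbon, turning 6-methoxy-1,3-benzothiazol-2-yl into 6-chloro-1,3-benzothiazol-2-yl. Within the data shown here, the only measured step, a 4.7-fold higher number from compound 1 to compound 2 (0.67 log units; beyond the scatter), is modest and beyond the scatter, but it swaps 4-nitrophenyl for 3-methoxyphenyl at a different place. Among the measured compounds shown here, no measured pair varies the group at the place now changed. A step of similar or smaller size is therefore expected, with direction poorly defined. For the measured compounds named here, the slight lean is towards a lower number, as compound 2 at 62600 nM is the higher of only two values. The estimated change is a 1.6-fold lower number from compound 2 to compound 3 (0.19 log units; within the scatter) and remains an expectation only. Compound 3 is expected at 40000 nM, with an estimated range from 14000 nM to 100000 nM in this assay for now.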

Compound 3, half-maximal inhibitory concentration: 36000 nM
The estimate for compound 3 lay 1.1-fold (0.05 log units) above the measured number, and the stated range covers the measured number.
By their numbers in this assay, from the lowest: compound 1; then compounds 3 and 2 (each within the scatter of the next).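

In this assay, among these compounds, the change from 6-methoxy-1,3-benzothiazol-2-yl to 6-chloro-1,3-benzothiazol-2-yl gives a 1.7-fold lower number from compound 2 to compound 3 (0.24 log units; within the scatter), which is the first reading at this place, as the earlier step changed 4-nitrophenyl to 3-methoxyphenyl elsewhere in the molecule. With the 3-methoxyphenyl group held constant, the two groups cannot be told apart at this place on this read-out, even though the hydrogen-bond acceptor counted for methoxy is absent from chloro. No measurement available here explains this result or bears on why the exchange leaves the number within the scatter.

Going by these compounds, this rests on a single pair, so it remains open whether chloro and methoxy would also read alike alongside the 4-nitrophenyl group of compound 1. Also open, on these data alone, is how a group of a different kind at this same place, such as an amine or a carboxylic acid, would read in this assay.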